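The source may hold more compounds than are shown below. What is called first, only, known or untested is meant among the compounds shown, and "the series" means these compounds.

Measured in a functional assay on MCF7 cells (Homo sapiens) for antiproliferative activity, read by sulforhodamine B assay, with a stated time of 48 h; on this read-out higher numbers stand for weaker inhibition and lower numbers for stronger inhibition:
- compound 1 `COc1ccccc1OS(=O)(=O)c1ccc(N2CCN(C)C2=O)cc1`: 26000 nM
- compound 2 `Cc1ccc(OS(=O)(=O)c2ccc(N3CCN(C)C3=O)cc2)cc1`: > 100000 nM (a limit of the assay)

Among the measured compounds shown here, compound 1 holds the only actual number so far. Compound 2 gives no number, only (the limit of > 100000 nM in this assay, at which 1 of the 2 values shown sits).

For the measured compounds named here, the one measured step is an at least 3.8-fold higher number from compound 1 to compound 2 (0.58 log units; beyond the scatter), with 4-methylphenyl in place of 2-methoxyphenyl on an oxygen. Compound 3 `CCCN1CCN(c2ccc(S(=O)(=O)Oc3ccccc3OC)cc2)C1=O` keeps the 2-methoxyphenyl of compound 1 and changes elsewhere: ethyl in place of hydrogen on a saturated chain carbon bound to an amide-type nitrogen in a ring, which reads as methyl to propyl. Going by the values given here, no measured step covers this place. The step to compound 2 shows only that this assay responds to a change at the other place, and its size cannot be carried over. No step beyond the scatter is therefore expected, and no direction can be favoured, though the uncertainty is wide. The estimate starts from compound 1 at 26000 nM.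

The step expected is a 1.1-fold lower number from compound 1 to compound 3 (0.03 log units; within the scatter).

Compound 3 is expected at 24000 nM, with an estimated range of 8000 nM to 80000 nM.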

Compound 3, half-maximal inhibitory concentration: 13000 nM
The estimate for compound 3 lay 1.8-fold (0.27 log units) above the measured number, and the stated range covers the measured number.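

In this assay, among the compounds shown here, the only measured change at this place, methyl to propyl, gives a 2.0-fold lower number from compound 1 to compound 3 (0.30 log units; within the scatter) and so stays within the scatter. With the 2-methoxyphenyl kept, ethyl in place of hydrogen on a saturated chain carbon bound to an amide-type nitrogen in a ring is therefore tolerated in this read-out, whereas the change at the other place, an at least 3.8-fold higher number from compound 1 to compound 2 (0.58 log units; beyond the scatter), lies beyond the scatter. Nothing measured here gives a cause for this reading at the chain, so the result stands as an observation on this one pair of compounds.

Going by these compounds, whether a longer chain such as butyl, or a chain ending in an amine or a carboxylic acid, would produce a step beyond the scatter remains open, as a single propyl example fixes no trend along the chain. Also open is whether the propyl group would behave in the same way with 4-methylphenyl in place of 2-methoxyphenyl, a combination that none of the compounds shown carries.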